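The compounds below may be only part of what the source reports. "The series", "measured", "known", "first", "only" and "open" are said of these compounds alone.

The compounds share a core on which an amino group sits on a double-bonded ring carbon. Compound 1 `O=C1C=C(N2CCC2)C(=O)c2c1nc1n2[C@H]2OC[C@@H](O)[C@H]2OC1` carries azetidin-1-yl there, compound 3 `O=C1C=C(Nc2ccc(I)cc2)C(=O)c2c1nc1n2[C@H]2OC[C@@H](O)[C@H]2OC1` carries (4-iodophenyl)amino, and compound 2 `CCc1ccc(NC2=CC(=O)c3c(nc4n3[C@H]3OC[C@@H](O)[C@H]3OC4)C2=O)cc1` carries (4-ethylphenyl)amino. In a functional assay on MCF7 cells (Homo sapiens) for inhibition, read by sulforhodamine B assay (on this read-out higher numbers stand for weaker inhibition and lower numbers for stronger inhibition), compound 1 reaches only a limit, > 16000 nM, which is the limit of > 16000 nM in this assay, at which 1 of the 3 values shown sits. In this assay compound 3 gives 2230 nM. In this assay compound 2 gives 8990 nM, the higher of the two numbers, with compound 3 a clear step below it. Going by the values given here, the one measured step is an at least 7.1-fold lower number from compound 1 to compound 3 (0.85 log units; beyond the scatter), moving from azetidin-1-yl to an arylamino. Compound 4 `O=C1C(NC2CCCCC2)=CC(=O)c2c1nc1n2[C@H]2OC[C@@H](O)[C@H]2OC1` differs from compound 2 by cyclohexyl in place of 4-ethylphenyl on an amine nitrogen. This change removes the aromatic ring while keeping the amine hydrogen, so it resembles that measured step only in part, yet that step points toward the arylamino carrying much of the potency. Compound 4 is therefore expected to give a weaker number than compound 2, a step of a 1.8-fold higher number from compound 2 to compound 4 (0.25 log units; within the scatter). The estimate for compound 4 in this assay is 16000 nM, between 6000 nM and 45000 nM, with a fair chance that only a limit is reported.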

Compound 4, half-maximal inhibitory concentration: > 16000 nM
Compound 4: a limit, no number (the forecaster's own chance of this, stated with the estimate: 50%); the middle value sits exactly at the limit.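

In this assay, going by these compounds, the change from an aromatic to a non-aromatic ring on the amine nitrogen reads as an at least 1.7-fold higher number from compound 2 to compound 4 (0.25 log units; that floor lies within the scatter), so only a floor within the scatter is known and the true size of the step stays open. Compound 4 gives a limit and no number, as compound 1 does: the limit of > 16000 nM in this assay, at which 2 of the 4 values shown sit. Compound 4 shows what compound 1 could not: with cyclohexylamino the amine hydrogen is kept, yet no number is reached, and among these four compounds only the arylamino compounds, compound 2 and compound 3, give one.

On these data alone, how far the true values of compound 1 and compound 4 lie beyond the limit remains open. So does how an unsubstituted phenylamino or a benzylamino group would read at this place.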